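This account rests on a few compounds, and the source may have more. Where it says the series, first, only, none or still open, it means among the compounds named here.

The measured compounds:
Compound 1 `COC(=O)c1ccc(CN(CCCc2c(N)nc(N)nc2O)c2ccc([N+](=O)[O-])c(F)c2F)cc1`, 55000 nM.
Compound 2 `CC(C)(C)OC(=O)CCC(Nc1ccc(CN(CCCc2c(N)nc(N)nc2O)c2cc(F)ccc2[N+](=O)[O-])cc1)C(=O)OC(C)(C)C`, 12000 nM.
Compound 3 `COC(=O)c1ccc(CN(CCCc2c(N)nc(N)nc2O)c2cc(F)ccc2[N+](=O)[O-])cc1`, 55000 nM.

All three were tested in a functional assay on CCRF-CEM cells (Homo sapiens) for cytotoxicity, in the absence of a further agent; on this read-out lower numbers stand for stronger inhibition and higher numbers for weaker inhibition. Compound 3 and compound 1 share the same core and differ in a single place, namely (2,3-difluoro-4-nitrophenyl in place of 5-fluoro-2-nitrophenyl on an amine nitrogen). The outcome of that exchange is no change at the digits printed from compound 3 to compound 1 (within the scatter), so the two compounds cannot be told apart on this read-out. Compound 2 is built on a different core; how its core differs from that of compound 3 is not broken down here. In this assay compound 2 gives 12000 nM, while compound 3 gives 55000 nM, and compound 2 thus stands with the lowest number of the three, its gap to both others lying beyond the scatter.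

Compound 4 `CC(C)(C)OC(=O)CCC(Nc1ccc(CN(CCCc2c(N)nc(N)nc2O)c2ccc([N+](=O)[O-])c(F)c2F)cc1)C(=O)OC(C)(C)C` has not yet been measured. It is related to compound 2 in the same way that compound 1 is related to compound 3: the difference is 2,3-difluoro-4-nitrophenyl in place of 5-fluoro-2-nitrophenyl on an amine nitrogen, at the same place on the amine nitrogen whose other neighbours are two saturated chain carbons, so this is the same change applied to the other core.

Because the same change earlier gave no change at the digits printed from compound 3 to compound 1 (within the scatter), the step now expected is no change at the digits printed from compound 2 to compound 4 (within the scatter). Within the data shown here, compound 4 is therefore estimated at 12000 nM, with a range from 5000 nM to 30000 nM, the range being wider than the scatter alone since the change has been seen on only one core.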

Compound 4, half-maximal inhibitory concentration: 20000 nM
For compound 4 the middle estimate is 1.7-fold (0.22 log units) below the measured one, and the stated range covers the measured number.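

In this assay, exchanging 5-fluoro-2-nitrophenyl for 2,3-difluoro-4-nitrophenyl on the amine nitrogen gives a 1.7-fold higher number from compound 2 to compound 4 (0.22 log units; within the scatter), and this step agrees with the one seen earlier on the other core: the same change on two cores in this assay, no change at the digits printed (within the scatter) from compound 3 to compound 1 and a 1.7-fold higher number (0.22 log units; within the scatter) from compound 2 to compound 4, 1.7-fold (0.22 log units) apart, within the scatter of two such steps. Within this small set, then, the exchange carries over from one core to the other, and on neither core can the two aryl groups be told apart on this cytotoxicity read-out. This does not show that the exchange would be equally silent on a third core or on any other read-out, since the agreement rests on just two pairs of compounds, and two steps within the scatter say nothing about why the exchange leaves the number where it is.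

The compounds shown leave open whether a free carboxylic acid in place of the tert-butyl esters, or in place of the methyl ester, would leave the two aryl groups just as hard to separate. They also leave open what a longer chain on the amine nitrogen, or an amine in place of the nitro group on the aryl ring, would do to the numbers on either core.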